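Vinyl sulfone to bromomethyl ketone on a bistrifluoromethyl ring

The compounds below may be only part of what the source reports. "The series", "measured", "known", "first", "only" and "open" are said of these compounds alone.

Compound 1 `C=CC(=O)Nc1cc(C(F)(F)F)cc(C(F)(F)F)c1` survives for 1.8 h in an ADME assay for pharmacokinetics, read by LC-MS, in phosphate buffer, with a stated time of 72 h, at pH 7.4, tested at 250 uM; on this read-out lower numbers stand for a shorter-lived compound and higher numbers for a longer-lived compound. Compound 2 `C=CS(=O)(=O)c1cc(C(F)(F)F)cc(C(F)(F)F)c1` gives in this assay only a limit, < 0.017 h. That reading sits at the limit of < 0.017 h in this assay, at which 1 of the 2 values shown sits. For the measured compounds named here, the one measured step, an at least 100-fold lower number from compound 1 to compound 2 (2.02 log units; beyond the scatter), shows how far a change of the group on this ring can move the half-life. Compound 3 `O=C(CBr)c1cc(C(F)(F)F)cc(C(F)(F)F)c1` differs from compound 2 by (bromomethyl)carbonyl in place of vinylsulfonyl on an aromatic carbon. Going by the values given here, no measured step covers this change, so the direction from the limit of compound 2 is uncertain. Compound 3 is expected to give about 0.05 h, between 0.005 h and 0.6 h. The expected step is then an at least 2.9-fold higher number from compound 2 to compound 3 (0.46 log units; beyond the scatter).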

Compound 3, half-life: < 0.017 h
Compound 3: only a limit was reported (the forecaster's own chance of this, stated with the estimate: 40%); at least 2.9-fold (0.46 log units) between middle value and limit.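

Replacing the (vinylcarbonyl)amino group of compound 1 with (bromomethyl)carbonyl on this aromatic carbon gives an at least 100-fold lower number from compound 1 to compound 3 (2.02 log units; beyond the scatter). So in this assay, vinylsulfonyl is no longer the only replacement shown to fall far short of compound 1. Compound 2 and compound 3 stand at the same limit, so the step between them cannot be read: the limit of < 0.017 h in this assay, at which 2 of the 3 values shown sit.

As far as these compounds go, how far the true half-life of either compound lies past that limit stays open. So does the half-life in this assay with an amine or a carboxylic acid at this place on the ring.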